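Aryl exchange on the carbonyl carbon: outlook for compound 3

The compounds below may be only part of what the source reports. "The series", "measured", "known", "first", "only" and "open" are said of these compounds alone.

Compound 1 `COc1cc(-c2cc(/C=C/C(=O)c3ccc(Cl)c(Cl)c3)[nH]n2)cc(OC)c1OC` is the reference point; in a functional assay on MOLT-4 cells (Homo sapiens) for cytotoxicity, read by sulforhodamine B assay, with a stated time of 48 h, tested at 0.01 uM (on this read-out lower numbers stand for a stronger effect and higher numbers for a weaker effect at the one concentration tested), compound 1 gives 98%. Compound 2 `COc1ccc(C(=O)/C=C/c2cc(-c3cc(OC)c(OC)c(OC)c3)n[nH]2)cc1` differs only in the aryl on the carbonyl carbon, and in this assay compound 2 gives 103%. Going by the values given here, the single step measured so far, a number 5 percentage points higher from compound 1 to compound 2 (within the scatter), is within the scatter, so compound 2 and compound 1 cannot be separated on these numbers; compound 2 sits at the upper of two values that are effectively the same.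

Compound 3 `COc1cc(-c2cc(/C=C/C(=O)c3ccc(F)c(F)c3)[nH]n2)cc(OC)c1OC` is the next point. Its change from compound 2: 3,4-difluorophenyl in place of 4-methoxyphenyl on a carbonyl carbon. Among the compounds with values here, the one step that bears on this is the step from compound 1 to compound 2, which swapped a dihalogenated phenyl for the 4-methoxyphenyl on the same carbonyl carbon and moved the read-out by only a number 5 percentage points higher from compound 1 to compound 2 (within the scatter). Compound 3 runs that exchange in the opposite direction with a different halogen pair, and nothing in the series indicates a move beyond the scatter.

For compound 3 the expected step is a number 4 percentage points lower from compound 2 to compound 3 (within the scatter), because the comparable step gave a number 5 percentage points higher from compound 1 to compound 2 (within the scatter). Compound 3 is therefore estimated at 99%, within 87% to 111%.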

Compound 3, a percentage reported as activity, at one concentration (the size of the read-out at that concentration, not a potency): 108%
The estimate for compound 3 lay 9 percentage points below the measured number; measured number inside the range.
By their numbers in this assay, from the lowest: compounds 1, 2 and 3 (each within the scatter of the next).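

The new compound completes a set of three aryl groups on the carbonyl carbon, and in this assay the exchange of 4-methoxyphenyl for 3,4-difluorophenyl gives a number 5 percentage points higher from compound 2 to compound 3 (within the scatter) while the exchange of 3,4-dichlorophenyl for 3,4-difluorophenyl gives a number 10 percentage points higher from compound 1 to compound 3 (within the scatter) on the same read-out. The second of these steps adds what the earlier pair could not show: replacing one halogen pair with another on the phenyl group at this place also leaves the compounds inseparable, so neither the methoxy-bearing nor the two dihalogenated aryl groups can be told apart here, and no order can be given among compounds 1, 2 and 3. Nothing available accounts for this flat result.

The compounds shown leave open whether any group at this place can move the read-out beyond the scatter, since all three aryl groups here carry only methoxy or halogen substituents. A phenyl group carrying an amine or a carboxylic acid on the same carbonyl carbon would test whether this flatness extends past these three aryl groups.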